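A few compounds are considered here, and "the series" means these few. Any claim that something is new, unique, unknown or untested is made for them only; others in the source may bear on it.

In an assay on isolated protein for inhibition of aldehyde dehydrogenase 1A1 (Homo sapiens) (a lower number here means a stronger inhibitor, a higher number a weaker inhibitor), the three measured compounds give:

compound 1 `Cn1ncc2c(=O)n(-c3ccccc3)c(SCc3cccc(F)c3)cc21` — 240 nM
compound 2 `CC(Sc1nc2c(cnn2C)c(=O)n1-c1ccccc1)c1ccccn1` — 242 nM
compound 3 `COc1ccccc1C(C)Sc1nc2c(cnn2C)c(=O)n1-c1ccccc1` — 445 nM

Compound 2 holds the second highest of the three numbers. Its nearest neighbour is compound 1, whose number is indistinguishable from it, and its furthest is compound 3, whose step a 1.8-fold higher number from compound 2 to compound 3 (0.26 log units; within the scatter) still lies within the scatter.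

Compound 4 `C[C@H](Sc1nc2c(cnn2C)c(=O)n1-c1ccccc1)c1ccccc1` is the unmeasured member. It differs from compound 2 by 1-phenylethyl in place of 1-(pyridin-2-yl)ethyl on a sulfur. Going by the values given here, the only measured step that bears directly on this exchange is the one from compound 2 to compound 3, which swapped the same pyridin-2-yl for 2-methoxyphenyl on the same chain carbon and moved the number only within the scatter. Compound 1, which carries an all-carbon six-membered aromatic ring on a different chain, gives the same number as compound 2. Among the compounds with values here, no measured step in this set shows that exchanging the aromatic ring at this position shifts this assay beyond the scatter, so the step of a 1.2-fold higher number from compound 2 to compound 4 (0.09 log units; within the scatter) is expected to be small.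

Compound 4 is therefore estimated at 300 nM, with a range from 120 nM to 750 nM.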

Compound 4, half-maximal inhibitory concentration: 1410 nM
Beside the measured number, compound 4's estimate is 4.7-fold (0.67 log units) below it; measured number above the stated range.
By their numbers in this assay, from the lowest: compounds 1, 2 and 3 (each within the scatter of the next); then compound 4.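

In this assay, going by these compounds alone, a 5.8-fold higher number from compound 2 to compound 4 (0.77 log units; beyond the scatter), the first exchange on this sulfur to lie beyond the scatter, so the group there is not freely interchangeable, as a 1.8-fold higher number from compound 2 to compound 3 (0.26 log units; within the scatter) alone had left possible. The loss of the ring nitrogen cannot be the whole reading: compound 3 also carries a carbon-only ring, as 2-methoxyphenyl, and its step stays within the scatter, while the 1-phenylethyl of compound 4 also brings a defined stereocentre. Nothing measured here gives a reason for the step.

Open, on these data alone, is whether the opposite stereocentre of compound 4 would give a similar number, since that stereocentre and the ring exchange enter together. Also open, as far as these compounds go, is how a 1-phenylethyl group bearing an amine or a carboxylic acid on its ring would read.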